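The compounds below may be only part of what the source reports. "The series", "measured", "known", "first", "only" and "open" are said of these compounds alone.

Of the compounds shown here, two carry numbers so far. Compound 1 `COc1ccc(Nc2nccc(-c3cn(C)c4ccccc34)n2)c(OC)c1` gives 610 nM in an assay for inhibition of MAP kinase-interacting serine/threonine-protein kinase 2 (Homo sapiens), read by TR-FRET; on this read-out higher numbers stand for weaker inhibition and lower numbers for stronger inhibition. Compound 2 `COc1ccc(Nc2nccc(-c3sc(SCc4cccnc4)nc3C)n2)c(OC)c1` gives 400 nM in this assay, the lower of the two numbers, with compound 1 as its nearest neighbour at a gap that sits within the scatter of repeated runs; on these two values alone no ordering of compound 1 and compound 2 can be stated.

Compound 3 `COc1ccc(Nc2nccc(-c3sc(SCCCN(C)C)nc3C)n2)c(OC)c1` has not been measured in this assay. It differs from compound 2 in one place: 2-(dimethylamino)ethyl in place of pyridin-3-yl on a saturated chain carbon bound to a sulfur. For the measured compounds named here, no pair of measured compounds differs in a single place; there is no step of known size to set beside this change, and the two values in hand give no hint of which way it should move the number. The expectation for compound 3 is a step from compound 2 that stays within the scatter, the estimated step being no change at the digits printed from compound 2 to compound 3 (within the scatter). On that basis compound 3 is expected to give about 400 nM in this assay, with a range from 130 nM to 1300 nM.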

Compound 3, inhibition constant: 1150 nM
Estimate against measurement, compound 3: 2.9-fold (0.46 log units) below, and the stated range covers the measured number.
By their numbers in this assay, from the lowest: compounds 2, 1 and 3 (each within the scatter of the next, the first and the last beyond it).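

At the saturated chain carbon bound to a sulfur, the series now has its first single-place change of known size: in this assay, 2-(dimethylamino)ethyl in place of pyridin-3-yl gives a 2.9-fold higher number from compound 2 to compound 3 (0.46 log units; beyond the scatter), a modest step that lies beyond the scatter. This place therefore does register in the read-out, and a group without a ring goes with the higher number in this one pair, although the two groups have equal counts of hydrogen-bond donors and acceptors and neither carries a net charge. No measurement in hand speaks to the origin of this step.

This single pair leaves open whether the step belongs to the loss of the pyridin-3-yl ring or to the arrival of the dimethylamino group, since both changes occur together. A plain phenyl ring at the same place, or a chain ending in a morpholine or a carboxylic acid, would help to separate these two readings.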